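Taking one methoxy off compound 2

The source may hold more compounds than are shown below. What is called first, only, known or untested is meant among the compounds shown, and "the series" means these compounds.

Compound 1 `COc1ccc(-c2nc(N3CCNCC3)nc3ccccc23)c(OC)c1` gives 50 ug/mL
Compound 2 `COc1cc(OC)c(-c2nc(N3CCN(C)CC3)nc3ccccc23)c(OC)c1` gives 50 ug/mL

In a functional assay on DU-145 cells (Homo sapiens) for antiproliferative activity, read by MTT assay (on this read-out higher numbers stand for weaker inhibition and lower numbers for stronger inhibition), compound 2 reads 50 ug/mL and so stands level with compound 1 at 50 ug/mL in the figures given, with no change beyond the scatter. On these data alone, the next compound, compound 3 `COc1ccc(-c2nc(N3CCN(C)CC3)nc3ccccc23)c(OC)c1`, has yet to be measured in this assay and its value is still open. It is reached from compound 2 by putting hydrogen in place of methoxy on an aromatic carbon at a place ortho to a large group and meta to two methoxy groups. Among the compounds with values here, no step between measured compounds that differ in one place is available to size such a change. Within the data shown here, the only guide is that compound 1 at 50 ug/mL and compound 2 at 50 ug/mL sit level. No step beyond the scatter is therefore expected in this assay and neither direction is favoured. The estimated change is no change at the digits printed from compound 2 to compound 3 (within the scatter) on this reading. Compound 3 is estimated at 50 ug/mL with an expected range from 28 ug/mL to 90 ug/mL in this measurement.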

Compound 3, half-maximal inhibitory concentration: 50 ug/mL
Compound 3: the middle estimate sits on the measured number at the digits printed, and the stated range covers the measured number.
By their numbers in this assay, from the lowest: compounds 1, 2 and 3 (each within the scatter of the next).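

Within the data shown here, the reading of no change at the digits printed from compound 2 to compound 3 (within the scatter) in this assay is the first direct measure of hydrogen in place of methoxy on this aromatic carbon, ortho to a large group and meta to two methoxy groups, and it shows that this methoxy can go without a step beyond the scatter. The same measurement separates a second change that the first two compounds could not isolate, since they differ in two places: methyl in place of hydrogen on the amine nitrogen in the ring gives no change at the digits printed from compound 1 to compound 3 (within the scatter) in this assay and so also leaves the figure where it was. Nothing at hand offers an explanation for either flat step.

On these data alone, it remains open whether a hydroxyl, a fluorine or a longer alkoxy chain on this aromatic carbon, or an ethyl or acetyl group on the ring nitrogen, would shift the reading in this assay at all. With no step beyond the scatter among these compounds, they do not show which groups at either place would matter on this read-out.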